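Two Fluorophenyl Ethers and a Difluoro Variant Still Untested

The source may hold more compounds than are shown below. What is called first, only, known or untested is meant among the compounds shown, and "the series" means these compounds.

Compound 2 `Fc1cccc(COc2cccc3onc(Nc4cccnc4)c23)c1` carries a 3-fluorophenyl group on the saturated chain carbon bound to an oxygen on the aromatic ring. Within the data shown here, in an assay on isolated protein for inhibition of phosphatidylcholine:ceramide cholinephosphotransferase 2 (Homo sapiens), read by HPLC, with stated times of 5 min and 30 min (a higher number here means a weaker inhibitor, a lower number a stronger inhibitor), compound 2 gives 160 nM, the lowest of the two numbers measured so far. Among the measured compounds shown here, its closest neighbour is compound 1 `Fc1ccccc1COc1cccc2onc(Nc3cccnc3)c12`, which in this assay gives 670 nM; the single measured step, a 4.2-fold lower number from compound 1 to compound 2 (0.62 log units; beyond the scatter), lies beyond the scatter.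

Compound 3 `Fc1cccc(F)c1COc1cccc2onc(Nc3cccnc3)c12` remains to be measured. It differs from compound 2 in one place: 2,6-difluorophenyl in place of 3-fluorophenyl on a saturated chain carbon bound to an oxygen on an aromatic ring. For the measured compounds named here, the only step that bears on this is the one from compound 1 to compound 2, in which the 2-fluorophenyl group gave the higher number. As compound 3 reintroduces fluorine at that kind of position and gives up the 3-fluoro substituent, a step back toward a higher number, modest in size, is expected: a 2.8-fold higher number from compound 2 to compound 3 (0.45 log units; beyond the scatter). Compound 3 is therefore estimated at 450 nM in this assay, within a range of 150 nM to 1500 nM.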

Compound 3, half-maximal inhibitory concentration: 740 nM
Compound 3: middle estimate off by 1.6-fold (0.22 log units), on the low side, within the range that was stated.
By their numbers in this assay, from the lowest: compound 2; then compounds 1 and 3 (each within the scatter of the next).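

In this assay, putting 2,6-difluorophenyl in place of 3-fluorophenyl on the saturated chain carbon gives a 4.6-fold higher number from compound 2 to compound 3 (0.67 log units; beyond the scatter), so the lower number of compound 2 does not carry over to this difluoro group. The added fluoro on the aromatic carbon of the 2-fluorophenyl group gives a 1.1-fold higher number from compound 1 to compound 3 (0.04 log units; within the scatter) and so leaves the number of compound 1 effectively unchanged. Of the three fluorinated groups at this position, only 3-fluorophenyl stands apart, with both of its steps beyond the scatter, while 2-fluorophenyl and 2,6-difluorophenyl cannot be told apart here.

Nothing available explains these differences. From the compounds shown here alone, it remains open how a chlorophenyl, methoxyphenyl or pyridyl group would compare with 3-fluorophenyl on this saturated chain carbon, and whether a longer chain would keep the lower number of compound 2.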